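Demethylation at the Aromatic Oxygen in Two Amidine Cores

The source may hold more compounds than are shown below. What is called first, only, known or untested is meant among the compounds shown, and "the series" means these compounds.

Compound 1 `COc1cc(C2=NCCN2)ccc1-c1cc2cc(C3=NCCN3)ccc2o1` carries a methoxy group and, in an ADME assay on L6 cells (Rattus norvegicus) for cytotoxicity (a higher number here means a weaker inhibitor, a lower number a stronger inhibitor), gives 7400 nM. Compound 3 `Oc1cc(C2=NCCN2)ccc1-c1cc2cc(C3=NCCN3)ccc2o1` differs from it only by hydrogen in place of methyl on an oxygen on an aromatic ring and, in this assay, compound 3 gives 150000 nM; the step of a 20-fold higher number from compound 1 to compound 3 (1.31 log units; beyond the scatter) is a large one. Compound 2 `COc1ccc(C(=N)N)cc1-c1cc2cc(C(=N)N)ccc2o1` belongs to a second core; the difference between the two cores is not broken down here. In this assay compound 2 gives 179000 nM, a number within the scatter of compound 3 and far above compound 1. Compound 4 `N=C(N)c1ccc(O)c(-c2cc3cc(C(=N)N)ccc3o2)c1` is the unmeasured counterpart of compound 2: it differs from compound 2 by hydrogen in place of methyl on an oxygen on an aromatic ring, the same change, at the same place, as that from compound 1 to compound 3. The step of a 2.2-fold higher number from compound 2 to compound 4 (0.35 log units; beyond the scatter) is expected to point the same way as the earlier one because a 20-fold higher number from compound 1 to compound 3 (1.31 log units; beyond the scatter) was large. Compound 2 already stands so high that the readout may reach the upper limit of this assay. Compound 4 is expected to give about 400000 nM, within a range from 150000 nM to 2000000 nM.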

Compound 4, half-maximal inhibitory concentration: > 217000 nM
Compound 4: no number, only a limit (the forecaster's own chance of this, stated with the estimate: 50%); the middle value lies beyond the limit too.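

In this assay, compound 4 is recorded only as a limit, > 217000 nM, and not as a number. The step is an at least 1.2-fold higher number from compound 2 to compound 4 (0.08 log units; that floor lies within the scatter), so the result is compatible with the direction seen on the core of compound 1 but does not establish that direction on the core of compound 2. Whether the change from methoxy to hydroxy carries over from one core to the other with the same size stays unsettled: the same change on two cores in this assay, a 20-fold higher number (1.31 log units; beyond the scatter) from compound 1 to compound 3 and an at least 1.2-fold higher number (0.08 log units; that floor lies within the scatter) from compound 2 to compound 4; the limit leaves it open whether they differ

The compounds shown leave open what happens in this assay when the oxygen on the aromatic ring carries a group other than methyl or hydrogen, such as ethyl or a longer chain. They also leave open whether an amine in place of the hydroxy group would behave alike on the two cores.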